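This account rests on a few compounds, and the source may have more. Where it says the series, first, only, none or still open, it means among the compounds named here.

Compound 1, `CN(C)/N=N/c1ccc([N+](=O)[O-])cc1C(N)=O`: 3.26
Compound 2, `CC(C)N(C)/N=N/c1ccc(C(N)=O)cc1`: 3.17
Compound 3, `C=CCN(C)/N=N/c1ccccc1C(N)=O`: 3.43

Of the compounds shown here, three have been measured in a functional assay on L1210 cells (Mus musculus) for antiproliferative activity; on this read-out higher numbers stand for higher potency (the scale is a negative logarithm) and lower numbers for lower potency. Compound 2 sits alongside the other two: the numbers of compound 1 and compound 3 both lie within the usual scatter of the number of compound 2, so none of the three can be told apart from another on this read-out.

The step under consideration leads from compound 2 to compound 4, `CCN(C)/N=N/c1ccc(C(N)=O)cc1`, which is not yet measured. The change is small: hydrogen in place of methyl on a saturated chain carbon bound to an amine nitrogen and a saturated chain carbon. Going by the values given here, no pair of measured compounds differing in one place is available, so there is no measured step to lean on. Given that compound 1, compound 2 and compound 3 all fall within the scatter of one another despite their different groups, the expectation for compound 4 is no step beyond the scatter, in either direction: a number 0.03 log units higher from compound 2 to compound 4 (within the scatter). The value expected for compound 4 in this assay is therefore 3.2, with a range from 2.8 to 3.6.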

Compound 4, logarithm of the reciprocal of the active concentration, log(1/C): 3.66
For compound 4 the middle estimate is 0.46 log units below the measured one; measured number above the stated range.
By their numbers in this assay, from the lowest: compounds 2, 1, 3 and 4 (each within the scatter of the next, the first and the last beyond it).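

In this assay, going by these compounds alone, the replacement of isopropyl(methyl)amino by ethyl(methyl)amino comes with a number 0.49 log units higher from compound 2 to compound 4 (beyond the scatter), the first step here between compounds that differ in one place. Within the data shown here, it shows that the number responds to losing one methyl on a saturated chain carbon bound to an amine nitrogen and a saturated chain carbon, which the earlier compounds, all within the scatter of one another and differing in more than one place, could not show. No measurement shown accounts for this step.

The compounds shown leave open how n-propyl, a butyl chain or 2-hydroxyethyl in place of the ethyl would read on this scale. They also leave open whether the same change from isopropyl to ethyl gives a step of similar size on the core of compound 1 or compound 3.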